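This account rests on a few compounds, and the source may have more. Where it says the series, first, only, none or still open, it means among the compounds named here.

Measured compounds in the series:

Compound 1 `O=C(O)c1cc2ccc(OCc3ccccc3)cc2[nH]c1=O` — in an assay on SiHa cells for inhibition of Monocarboxylate transporter 4 (Homo sapiens), read by scintillation counting, with a stated time of 24 h (on this read-out lower numbers stand for stronger inhibition and higher numbers for weaker inhibition), compound 1 gives > 30000 nM, which is a limit of the assay and not a number.
Compound 2 `Cn1c(=O)c(C(=O)O)cc2ccc(OCc3ccccc3)cc21` — in this assay compound 2 gives > 30000 nM, again a limit.
Compound 3 `CCn1c(=O)c(C(=O)O)cc2ccc(OCc3ccccc3)cc21` — in this assay compound 3 gives > 30000 nM, also a limit.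

Compound 3 therefore stands at the assay limit, and no order among the three can be drawn, since (the limit of > 30000 nM in this assay, at which 3 of the 3 values shown sit). Of the measured steps, a step that the two limits leave unreadable from compound 1 to compound 2, a step that the two limits leave unreadable from compound 1 to compound 3 and a step that the two limits leave unreadable from compound 2 to compound 3 are all unreadable for the same reason: both ends sit at the limit.

Compound 4 `O=C(O)c1cc2ccc(OCc3ccccc3)cc2n(Cc2ccccc2)c1=O` is the next member, differing from compound 3 by phenyl in place of methyl on a saturated chain carbon bound to an aromatic nitrogen. The nearest measured steps bear on it only by analogy with substitution on the same saturated chain carbon bound to the aromatic nitrogen, and those steps give no readable size. No step beyond the scatter can be expected in this assay from this change, and the expectation is that compound 4 also returns a limit. The estimated step of a number no higher from compound 3 to compound 4 (the limit leaves the size open) is therefore taken as none. For compound 4 the estimate is 30000 nM, with a range from 5000 nM to 150000 nM, most probably reported only as a limit.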

Compound 4, half-maximal inhibitory concentration: > 30000 nM
Compound 4: a limit, no number; the forecaster's own chance of this, stated with the estimate: 80%; the middle value sits exactly at the limit.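

In this assay compound 4 gives > 30000 nM as a limit of the assay and not a number. Among these compounds, no step from compound 1, compound 2 or compound 3 to compound 4 can be read, because both ends of each step sit at the same limit: the limit of > 30000 nM in this assay, at which 4 of the 4 values shown sit. The compounds shown leave open which substituent on the aromatic nitrogen, if any, would give a value inside the range of the assay.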